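The compounds below may be only part of what the source reports. "The series", "measured", "known", "first", "only" and "open" are said of these compounds alone.

Compound 1 `COc1cc(C(=O)c2cn(-c3ccccc3)cc2-c2ccccc2Br)cc(OC)c1OC`: 190 nM
Compound 2 `COc1cc(C(=O)c2cn(-c3ccccc3)cc2-c2cccc([N+](=O)[O-])c2)cc(OC)c1OC`: 50 nM

For the measured compounds named here, in a functional assay on MCF7 cells (Homo sapiens) for cytotoxicity, read by MTT assay, with a stated time of 96 h (a higher number here means a weaker inhibitor, a lower number a stronger inhibitor), compound 2 gives 50 nM, the lower of the two numbers so far. Compound 3 `COc1ccccc1-c1cn(-c2ccccc2)cc1C(=O)c1cc(OC)c(OC)c(OC)c1` keeps the core of compound 2 but has 2-methoxyphenyl in place of 3-nitrophenyl on an aromatic carbon. Going by the values given here, only one measured step bears on this change: a 3.8-fold lower number from compound 1 to compound 2 (0.58 log units; beyond the scatter). That step also removed a 2-bromophenyl in favour of 3-nitrophenyl, so compound 3 partly reverses it, and 2-methoxyphenyl shares its numbering with the 2-bromophenyl of compound 1. Among the compounds with values here, no measured compound carries 2-methoxyphenyl, so this reasoning is loose. A return towards the higher number of compound 1, at 190 nM, is therefore expected, though probably not all the way. The estimated step is a 2.4-fold higher number from compound 2 to compound 3 (0.38 log units; beyond the scatter). For compound 3 the expected value is 120 nM, with an estimated range from 30 nM to 450 nM.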

Compound 3, half-maximal inhibitory concentration: 190 nM
Beside the measured number, compound 3's estimate is 1.6-fold (0.20 log units) below it, within the range that was stated.
By their numbers in this assay, from the lowest: compound 2; then compounds 1 and 3 (each within the scatter of the next).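

In this assay the change from 3-nitrophenyl to 2-methoxyphenyl gives a 3.8-fold higher number from compound 2 to compound 3 (0.58 log units; beyond the scatter) and leaves compound 2 with the lowest number of the three. Replacing bromo with methoxy on the phenyl ring gives no change at the digits printed from compound 1 to compound 3 (within the scatter) and so shows that, at this position on the five-membered aromatic ring, 2-bromophenyl and 2-methoxyphenyl cannot be told apart in this cell test. No supporting measurement is available to explain either result. Compound 2 differs from compounds 1 and 3 in both the group on the phenyl ring and where that group sits, so these compounds cannot separate the two influences. Open too, from the compounds shown here alone, is where 3-methoxyphenyl and 2-nitrophenyl would fall, and what an amine or a carboxylic acid on this phenyl ring would do.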